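Swapping the aryl group on the amide nitrogen

This account rests on a few compounds, and the source may have more. Where it says the series, first, only, none or still open, it means among the compounds named here.

Of the compounds shown here, two sharing one core have been measured so far in a functional assay on MDA-MB-231 cells (Homo sapiens) for cytotoxicity, read by MTT assay; on this read-out higher numbers stand for weaker inhibition and lower numbers for stronger inhibition. Compound 1 (`CCn1cc(C(=O)Nc2ccc(Cl)cn2)c(=O)c2cc(F)c(N3CCNC(C)C3)c(F)c21`) gives 4800 nM, and compound 2 (`CCn1cc(C(=O)Nc2ccc(C)c([N+](=O)[O-])c2)c(=O)c2cc(F)c(N3CCNC(C)C3)c(F)c21`) gives 4200 nM. These two numbers cannot be told apart, so compound 2 stands level with compound 1 within the normal scatter of repeated measurements.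

Compound 3 (`CCn1cc(C(=O)Nc2ccc(C(C)=O)cc2)c(=O)c2cc(F)c(N3CCNC(C)C3)c(F)c21`) is the next to be tested. It has 4-acetylphenyl in place of 4-methyl-3-nitrophenyl on an amide-type nitrogen, and the counted difference from compound 2 is 4-acetylphenyl in place of 4-methyl-3-nitrophenyl on an amide-type nitrogen. The rest of the molecule stays the same.

For the measured compounds named here, only one measured step bears on this change. Compound 1 and compound 2 differ in the same place, and their step is a 1.1-fold lower number from compound 1 to compound 2 (0.06 log units; within the scatter), so that exchange of groups produced no difference beyond the scatter. Going by the values given here, a single step is thin evidence, and no measured compound here carries 4-acetylphenyl.

The expected step in this assay is a 1.1-fold higher number from compound 2 to compound 3 (0.03 log units; within the scatter), which means none beyond the scatter. For compound 3 the estimated value is 4500 nM, with an expected range from 1800 nM to 11000 nM.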

Compound 3, half-maximal inhibitory concentration: 5600 nM
Beside the measured number, compound 3's estimate is 1.2-fold (0.09 log units) below it; low and high end bracket the measured number.
By their numbers in this assay, from the lowest: compounds 2, 1 and 3 (each within the scatter of the next).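

With a third aryl group on the amide-type nitrogen, the picture from the first pair holds in this assay: the data show a 1.3-fold higher number from compound 2 to compound 3 (0.12 log units; within the scatter), and also a 1.2-fold higher number from compound 1 to compound 3 (0.07 log units; within the scatter). So 5-chloropyridin-2-yl, 4-methyl-3-nitrophenyl and 4-acetylphenyl cannot be told apart here, even though the latest exchange removes the nitro-bearing ring and changes the group's count of heavy atoms and of hydrogen-bond acceptors. No supporting measurement is available to explain why these three groups give such similar numbers.

All three groups shown are six-membered aromatic rings joined directly to the amide-type nitrogen, so this small set says nothing about a carboxylic acid or an amine carried on that ring, or about a longer carbon chain in place of the ring. It also leaves open whether these same exchanges would stay within the scatter on a different core, or in cells other than those used for this read-out.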